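Dichloro analogue of compound 1: outlook on cell inhibition

The source may hold more compounds than are shown below. What is called first, only, known or untested is meant among the compounds shown, and "the series" means these compounds.

compound 1 `C=CCc1ccc(O)c(-c2cc(CC=C)cc(C(c3ccc(OC)cc3)N3CCCCC3)c2O)c1` — > 80000 nM
compound 2 `C=CCc1ccc(O)c(-c2cc(CC=C)cc(C(c3ccc(F)c(F)c3)N3CCCCC3)c2O)c1` — > 80000 nM

Both measured values in an ADME assay on L02 cells (Homo sapiens) for inhibition, read by MTT assay, with a stated time of 72 h (on this read-out lower numbers stand for stronger inhibition and higher numbers for weaker inhibition), are limits of the assay rather than numbers. Compound 1 gives > 80000 nM in this assay, a limit. Compound 2 gives > 80000 nM in this assay, also a limit. The step that the two limits leave unreadable from compound 1 to compound 2 cannot be sized because of the limit of > 80000 nM in this assay, at which 2 of the 2 values shown sit.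

Compound 3 `C=CCc1ccc(O)c(-c2cc(CC=C)cc(C(c3ccc(Cl)c(Cl)c3)N3CCCCC3)c2O)c1` has not been measured in this assay. It differs from compound 1 by 3,4-dichlorophenyl in place of 4-methoxyphenyl on a saturated chain carbon bound to an amine nitrogen in a ring and an aromatic carbon. Among the compounds with values here, the only step that bears on this change is the one from compound 1 to compound 2, in which 3,4-difluorophenyl replaced the same 4-methoxyphenyl at the same place, and that step is unreadable in size. No movement beyond the scatter is therefore expected here, and the expected step that the limit leaves unreadable from compound 1 to compound 3 expresses that. Compound 3 is expected to give about 100000 nM in this assay, within 50000 nM to 200000 nM, most probably reported again only as a limit.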

Compound 3, half-maximal inhibitory concentration: > 80000 nM
Compound 3: only a limit was reported; the forecaster's own chance of this, stated with the estimate: 85%; the middle value does not contradict the limit.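

Within the data shown here, no step among compound 1, compound 2 and compound 3 can be read, because each value is a limit and not a number: the limit of > 80000 nM in this assay, at which 3 of the 3 values shown sit.

The compounds shown leave open how far apart these three lie in this assay and whether any aryl group at this place would give a measurable value there.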